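The source may hold more compounds than are shown below. What is called first, only, known or untested is meant among the compounds shown, and "the series" means these compounds.

Compound 2 `CC(C)Cn1nc(C(=O)N[C@H]2COc3ccccc3N(C)C2=S)nc1Cc1ccccc1` stands only at a limit of a toxicity assay on HT-29 cells (Homo sapiens) for cytotoxicity; on this read-out higher numbers stand for lower toxicity in this test and lower numbers for higher toxicity in this test: in this assay compound 2 gives > 100000 nM, a limit of the assay rather than a number. Compound 1 `CC(C)n1nc(C(=O)N[C@H]2COc3ccccc3N(C)C2=S)nc1Cc1ccccc1` likewise reaches only a limit, giving > 100000 nM in this assay. Compound 3 `CN1C(=S)[C@@H](NC(=O)c2nc(Cc3ccccc3)n(C3CCCCC3)n2)COc2ccccc21` also gives > 100000 nM in this assay, again a limit. The step from compound 2 to compound 4 `CN1C(=S)[C@@H](NC(=O)c2nc(Cc3ccccc3)n(C3CCOC3)n2)COc2ccccc21` changes the group on an aromatic nitrogen, (oxolan-3-yl in place of isobutyl on an aromatic nitrogen). The measured steps at the same place, a step that the two limits leave unreadable from compound 1 to compound 2, a step that the two limits leave unreadable from compound 1 to compound 3 and a step that the two limits leave unreadable from compound 2 to compound 3, cannot be read in size, because the limit of > 100000 nM in this assay, at which 3 of the 3 values shown sit, shows every value at the limit. No step beyond the scatter in this assay is therefore expected from compound 2 to compound 4, the estimated step being a step that the limit leaves unreadable from compound 2 to compound 4. For compound 4 the estimated value in this assay is 150000 nM, with a range from 60000 nM to 400000 nM, most likely reported again only as a limit.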

Compound 4, half-maximal cytotoxic concentration: > 100000 nM
Compound 4: a limit, no number; the forecaster's own chance of this, stated with the estimate: 85%; the middle value is on the limit's open side.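

The steps from compound 4 to compound 1, compound 2 and compound 3 in this assay cannot be read in size, because all four compounds stand at a limit: the limit of > 100000 nM in this assay, at which 4 of the 4 values shown sit.

The compounds shown leave open whether any group on the aromatic nitrogen would give a number rather than a limit in this assay.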